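Working notes: from compound 2 to compound 3

A few compounds are considered here, and "the series" means these few. Any claim that something is new, unique, unknown or untested is made for them only; others in the source may bear on it.

Among the measured compounds shown here, in a functional assay on HepG2 cells (Homo sapiens) for inhibition, with a stated time of 96 h (a lower number here means a stronger inhibitor, a higher number a weaker inhibitor), compound 2 `CC1(C)C/C(=N\NC(N)=S)c2cc(O)ccc2O1` gives 140000 nM, the highest of the two numbers measured so far. Compound 1 `CCC1(C)C/C(=N\NC(N)=O)c2cc(O)ccc2O1` gives 60000 nM in this assay, a lower number; these two compounds differ in more than one place, so the pair shows only its two values. Compound 3 `CCC1(C)C/C(=N\NC(N)=S)c2cc(O)ccc2O1` is yet to be measured in this assay; it differs from compound 2 by methyl in place of hydrogen on a saturated chain carbon bound to a saturated ring carbon. For the measured compounds named here, no measured pair isolates this change, so the step of a 1.4-fold lower number from compound 2 to compound 3 (0.15 log units; within the scatter) is expected to be small, at most modestly toward a lower number. Compound 3 is estimated at 100000 nM, within 40000 nM to 250000 nM.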

Compound 3, half-maximal inhibitory concentration: 60000 nM
Compound 3: middle estimate off by 1.7-fold (0.22 log units), on the high side; the range from low to high includes it.
By their numbers in this assay, from the lowest: compounds 1 and 3 (each within the scatter of the next); then compound 2.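

In this assay, among the compounds shown here, methyl in place of hydrogen on a saturated chain carbon bound to a saturated ring carbon now has a measured step, a 2.3-fold lower number from compound 2 to compound 3 (0.37 log units; beyond the scatter), a modest move that no earlier pair could isolate. With the ethyl group present in both compounds, the sulfur and oxygen forms of the group on the amine nitrogen show no change at the digits printed from compound 1 to compound 3 (within the scatter), so this assay does not separate them. As far as these compounds go, whether a longer chain than ethyl, or a carboxylic acid at its end, moves the number further stays open. Nothing at hand bears on what lies behind either step.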